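This account rests on a few compounds, and the source may have more. Where it says the series, first, only, none or still open, it means among the compounds named here.

Compound 1 `CC(C)n1nc(-c2ccnc3[nH]c(C4CCN(CC(=O)N(C)C)CC4)cc23)ccc1=O` stands lowest of the three numbers in a physicochemical assay for solubility, in phosphate buffer, at pH 7.4; a lower number here means a less soluble compound, a higher number a more soluble compound: compound 1 gives 11000 nM. Compound 2 `COc1cc(C(=O)N2CCCC2)ccc1-c1ccnc2[nH]c(C3CCOCC3)cc12` gives 15000 nM, which sits within the scatter of compound 1, so the two cannot be ordered. Compound 3 `CN(C)C(=O)CN1CCC(c2cc3c(-c4ccc(=O)n(C5CCOCC5)c4)ccnc3[nH]2)CC1` gives 840000 nM, far beyond the scatter of both. Compound 4 `COc1cc(F)ccc1-c1ccnc2[nH]c(C3CCN(CC(=O)N(C)C)CC3)cc12` is not yet measured. Among the measured compounds shown here, it differs from compound 1 in one place: a group of 9 heavy atoms (7 carbon, 1 oxygen, 1 fluorine; one six-membered aromatic ring of carbon only) in place of a group of 10 heavy atoms (7 carbon, 2 nitrogen, 1 oxygen; one six-membered aromatic ring with 2 hetero atoms), on an aromatic carbon No measured pair shows this exact swap, so the expectation rests on the ring types involved and on compound 2, which likewise carries no six-membered aromatic ring with hetero atoms at that place and gives 15000 nM. A modest fall in solubility is expected, near the edge of the scatter, a 2.2-fold lower number from compound 1 to compound 4 (0.34 log units; beyond the scatter). Compound 4 is estimated at 5000 nM, within a range from 1500 nM to 18000 nM.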

Compound 4, solubility: 38000 nM
For compound 4 the middle estimate is 7.6-fold (0.88 log units) below the measured one; the measured number lies above the stated range.
By their numbers in this assay, from the lowest: compounds 1 and 2 (each within the scatter of the next); then compound 4; then compound 3.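

At this aromatic carbon of the core, the ring with 2 hetero atoms can give way to 4-fluoro-2-methoxyphenyl, a ring of carbon only, and a 3.5-fold higher number from compound 1 to compound 4 (0.54 log units; beyond the scatter) appears in this assay as a gain rather than a loss. In this one pair, the carbon-only ring with fewer hydrogen-bond acceptors goes with the higher number. Nothing measured here explains the rise. The compounds shown leave open whether the fluorine, the methoxy or the ring itself carries this step; a plain phenyl or a pyridine ring here would help separate them.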